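This account rests on a few compounds, and the source may have more. Where it says the series, first, only, none or still open, it means among the compounds named here.

Among the compounds with values here, compound 2, `O=C(/C=C\Nc1ccc(Cl)cc1)c1cn(-c2ccccc2)nc1-c1ccc(Cl)cc1`, gives 3890 nM in a functional assay on PC-3 cells (Homo sapiens) for antiproliferative activity, read by MTT assay, with a stated time of 48 h; on this read-out higher numbers stand for weaker inhibition and lower numbers for stronger inhibition; this is the only full number among the values shown. Compound 1, `O=C(/C=C\Nc1ccc(C(F)(F)F)cc1)c1cn(-c2ccccc2)nc1-c1ccc(F)cc1`, reaches only the limit > 50000 nM in this assay, a limit of the measurement rather than a number. Compound 3, `O=C(/C=C\Nc1ccc(C(F)(F)F)cc1)c1cn(-c2ccccc2)nc1-c1ccc(Cl)cc1`, has not yet been measured in this assay. The change from compound 2 to compound 3 is trifluoromethyl in place of chloro on an aromatic carbon. Within the data shown here, no step between two measured compounds isolates this change, since compound 1 also differs from compound 3 at the other aromatic ring. Still, compound 1 carries the same trifluoromethyl group and sits at the limit > 50000 nM. Compound 3 is therefore expected to be weaker than compound 2, with the step of a 3.9-fold higher number from compound 2 to compound 3 (0.59 log units; beyond the scatter) lying beyond the scatter. Compound 3 is estimated at 15000 nM, within a range from 5000 nM to 50000 nM, with a fair chance that only a limit is reported.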

Compound 3, half-maximal inhibitory concentration: > 50000 nM
Compound 3: a limit, no number (the forecaster's own chance of this, stated with the estimate: 35%); at least 3.3-fold (0.52 log units) between middle value and limit.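

In this assay, within the data shown here, the change from (4-chlorophenyl)amino to (4-(trifluoromethyl)phenyl)amino, with the rest of the molecule unchanged, gives an at least 12-fold higher number from compound 2 to compound 3 (1.10 log units; beyond the scatter), the first step that isolates trifluoromethyl in place of chloro at this position. Compound 3 carries a limit and not a number, so this step sets only a minimum for the size of the change. The step from compound 1 to compound 3 cannot be read, so chloro in place of fluoro on the other aromatic ring shows nothing here: the limit of > 50000 nM in this assay, at which 2 of the 3 values shown sit.

The compounds shown leave open whether another group at this position, such as a methoxy group, a bromine atom or an amine, would give a measurable value. On these data alone, whether fluoro in place of chloro on the other aromatic ring would change the value of compound 2 also remains open.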